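Series notes: fluoro analogue of compound 2

The source may hold more compounds than are shown below. What is called first, only, known or untested is meant among the compounds shown, and "the series" means these compounds.

Measured compounds:
Compound 1, `c1ccc(/N=c2\ssnc2-c2ccccc2)cc1`: in a functional assay on MDA-MB-231 cells (Homo sapiens) for antiproliferative activity, read by MTT assay, with a stated time of 72 h (on this read-out lower numbers stand for stronger inhibition of growth and higher numbers for weaker inhibition of growth), compound 1 gives > 10000 nM, which is a limit of the assay rather than a number.
Compound 2, `S=c1ssnc1-c1ccccc1`: in this assay compound 2 gives > 10000 nM, likewise a limit rather than a number.

Compound 2 therefore stands at the limit, and the two values shown both sit there (the limit of > 10000 nM in this assay, at which 2 of the 2 values shown sit). Within the data shown here, no step between measured compounds is available, so the numbers give no direction for any change. Compound 3, `Fc1ccc(-c2nssc2=S)cc1`, differs from compound 2 in one place: fluoro in place of hydrogen on an aromatic carbon. With both measured compounds at the limit, nothing in the series indicates that this change moves the read-out, and the expected step that the limit leaves unreadable from compound 2 to compound 3 is none beyond the scatter. Compound 3 is estimated at 20000 nM, within 5000 nM to 80000 nM, with a strong chance that this assay again reports only a limit.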

Compound 3, concentration for 50% growth inhibition: > 10000 nM
Compound 3: only a limit was reported (the forecaster's own chance of this, stated with the estimate: 80%); the middle value lies beyond the limit too.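

No step from compound 2 to compound 3 can be read, because both values are limits rather than numbers: the limit of > 10000 nM in this assay, at which 3 of the 3 values shown sit.

The compounds shown leave open whether fluoro in place of hydrogen changes growth inhibition at all, and what any of the three true values is.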